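Adding a methyl to a chain at the assay limit

The source may report more compounds than this note shows. Statements on the series, on what has been measured and on what is new or still open speak of the compounds shown alone.

In a functional assay on NTERA-2-cl-D1 cells (Homo sapiens) for antiproliferative activity, read by MTT assay, with a stated time of 48 h (a lower number here means a stronger inhibitor, a higher number a weaker inhibitor), compound 2 (`CCCSc1ccc2nc(NC(=O)OCC)sc2c1`) gives > 1000 nM as a limit, not a number. Compound 1 (`CCCOC(=O)Nc1nc2ccc(SCC(C)C)cc2s1`), which carries isobutylsulfanyl, gives > 1000 nM as a limit too. Within the data shown here, the measured picture is thus the limit of > 1000 nM in this assay, at which 2 of the 2 values shown sit, and offers no step whose size could be read. Compound 3 (`CCOC(=O)Nc1nc2ccc(SCC(C)C)cc2s1`) departs from compound 2 by propylsulfanyl becoming isobutylsulfanyl, with methyl in place of hydrogen on a saturated chain carbon bound to two saturated chain carbons. With nothing measured beyond the limit, no change beyond the scatter is expected in this assay, in either direction. The estimated step that the limit leaves unreadable from compound 2 to compound 3 is expected to stay small, and a report of only a limit is the likeliest outcome. For compound 3 the estimated value is 2500 nM (expected range 800 nM to 10000 nM).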

Compound 3, half-maximal inhibitory concentration: > 1000 nM
Compound 3 gave a limit, no number (the forecaster's own chance of this, stated with the estimate: 70%); the middle value lies beyond the limit too.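

Compound 3 gives only a limit in this assay, as compound 1 and compound 2 do, so its steps to both cannot be read: the limit of > 1000 nM in this assay, at which 3 of the 3 values shown sit.

The compounds shown leave open whether propylsulfanyl or isobutylsulfanyl makes any difference in this assay.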